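Chloro for allyloxy: compound 3 from compound 2

This account rests on a few compounds, and the source may have more. Where it says the series, first, only, none or still open, it means among the compounds named here.

Measured so far:
Compound 1, `CCCNNC(=O)c1ccc(CNC(=O)c2cc3cc(O)ccc3o2)cc1`: > 10000 nM (a limit)
Compound 2, `C=CCOc1ccc2oc(C(=O)NCc3ccc(C(=O)NNCCC)cc3)cc2c1`: > 10000 nM (a limit)

In an assay on isolated protein for inhibition of protein deacetylase HDAC6 (Homo sapiens), read by fluorescence, with a stated time of 2 h (a lower number here means a stronger inhibitor, a higher number a weaker inhibitor), compound 1 gives only the limit > 10000 nM. Compound 2 likewise gives only the limit > 10000 nM. Both values rest at the limit of > 10000 nM in this assay, at which 2 of the 2 values shown sit, so the step that the two limits leave unreadable from compound 1 to compound 2, allyl in place of hydrogen on an oxygen on an aromatic ring, cannot be read in size or direction. Compound 2 thus stands at the limit of this assay and nowhere more precisely.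

Compound 3, `CCCNNC(=O)c1ccc(CNC(=O)c2cc3cc(Cl)ccc3o2)cc1`, differs from compound 2 by chloro in place of allyloxy on an aromatic carbon. Going by the values given here, no measured step touches this change; the one step in hand is unreadable, and both anchors are limits. With nothing pointing to a gain in potency, compound 3 is expected to remain at or near the limit, and the step that the limit leaves unreadable from compound 2 to compound 3 is estimated to be small or unresolved. Compound 3 is estimated at 15000 nM, with a range from 4000 nM to 60000 nM, most likely reported again as a limit.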

Compound 3, half-maximal inhibitory concentration: > 10000 nM
Compound 3: no number, only a limit (the forecaster's own chance of this, stated with the estimate: 80%); the middle value lies beyond the limit too.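

No step among compound 1, compound 2 and compound 3 can be read in this assay, because all three values are limits rather than numbers: the limit of > 10000 nM in this assay, at which 3 of the 3 values shown sit.

The compounds shown leave open how hydroxy, allyloxy and chloro on the aromatic carbon compare in potency, and what any of them contributes to inhibition.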